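Fluoro for Chloro on the Benzyl Arm of Compound 1

A few compounds are considered here, and "the series" means these few. Any claim that something is new, unique, unknown or untested is made for them only; others in the source may bear on it.

Measured in a functional assay on DU-145 cells (Homo sapiens) for inhibition, read by trypan blue exclusion, with a stated time of 96 h; on this read-out lower numbers stand for stronger inhibition of growth and higher numbers for weaker inhibition of growth:
Compound 1 `Cc1ccsc1/C=C(/SCc1ccc(Cl)cc1)C(=O)c1ccc(Cl)cc1`: 50000 nM
Compound 2 `O=C(/C(=C\c1ccc(Br)cc1)SCc1ccc(Cl)cc1)c1ccc(Cl)cc1`: 1000 nM
Compound 3 `O=C(/C(=C\c1cccc(Cl)c1Cl)SCc1ccc(Cl)cc1)c1ccc(Cl)cc1`: 10000 nM

Compound 1 gives the highest number of the three: a 5.0-fold lower number from compound 1 to compound 3 (0.70 log units; beyond the scatter), and a 50-fold lower number from compound 1 to compound 2 (1.70 log units; beyond the scatter). Compound 4 `Cc1ccsc1/C=C(/SCc1ccc(F)cc1)C(=O)c1ccc(Cl)cc1` differs from compound 1 in one place: fluoro in place of chloro on an aromatic carbon. Every measured step instead alters the group on the double-bonded chain carbon, so none of them speaks directly to a change on the 4-chlorobenzyl; a 10-fold higher number from compound 2 to compound 3 (1.00 log units; beyond the scatter), like the other two steps, concerns that other position only. For the measured compounds named here, with no step bearing on this change, compound 4 is expected to stay close to compound 1, within the scatter: no change at the digits printed from compound 1 to compound 4 (within the scatter). The estimate for compound 4 in this assay is 50000 nM, ranging from 20000 nM to 120000 nM.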

Compound 4, concentration for 50% growth inhibition: 50000 nM
Compound 4: the middle estimate sits on the measured number at the digits printed; low and high end bracket the measured number.
By their numbers in this assay, from the lowest: compound 2; then compound 3; then compounds 1 and 4 (each within the scatter of the next).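

In this assay, for the compounds shown here, the one step on the 4-chlorobenzyl arm reads no change at the digits printed from compound 1 to compound 4 (within the scatter) and so, unlike the steps at the double-bonded chain carbon, stays within the scatter. On the core of compound 1, then, this aromatic carbon takes fluoro in place of chloro with no visible effect on the read-out. Nothing available explains this result.

Going by these compounds, whether the swap reads the same alongside the 4-bromophenyl of compound 2 stays open. So does the effect of a methoxy group or an amine at this place.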